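Bombesin receptor subtype-3 agonists: imidazole substituent exchange

A few compounds are considered here, and "the series" means these few. Any claim that something is new, unique, unknown or untested is made for them only; others in the source may bear on it.

compound 1 `CCCCc1cnc(C(CCC)Cc2ccc(-c3ccccc3C(=O)O)cc2)[nH]1`: 1180 nM
compound 2 `O=C(O)c1ccccc1-c1ccc(CCc2ncc(C3CCCCC3)[nH]2)cc1`: 375 nM

Among the measured compounds shown here, in an in vitro functional assay on cells for agonist activity at Bombesin receptor subtype-3 (Homo sapiens), read by luminescence and calcium flux (on this read-out lower numbers stand for an effect already at smaller amounts and higher numbers for an effect only at larger amounts of compound), compound 2 gives 375 nM, the lowest of the two numbers measured so far. Compound 1 gives 1180 nM in this assay, a higher number beyond the scatter. Compound 3 `COc1ccc(Cc2cnc(CCc3ccc(-c4ccccc4C(=O)O)cc3)[nH]2)cc1` differs from compound 2 in one place: 4-methoxybenzyl in place of cyclohexyl on an aromatic carbon. For the measured compounds named here, no step between measured compounds isolates this change, so the expectation rests on compound 2 alone. The change is expected to move the number only a little, a 1.3-fold higher number from compound 2 to compound 3 (0.12 log units; within the scatter), if at all beyond the scatter. Compound 3 is estimated at 500 nM, with a range from 150 nM to 2000 nM.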

Compound 3, half-maximal effective concentration: 5360 nM
Estimate against measurement, compound 3: 11-fold (1.03 log units) below, and the stated range ends below it.
By their numbers in this assay, from the lowest: compound 2; then compound 1; then compound 3.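

The group on this aromatic carbon, next to the ring nitrogen, is not freely exchangeable: 4-methoxybenzyl in place of cyclohexyl gives a 14-fold higher number from compound 2 to compound 3 (1.16 log units; beyond the scatter). Among the compounds shown here, this is the first step that reads this position on its own, and it shows that the number here depends strongly on the group carried. Nothing available explains the size of this step.

The compounds shown leave open whether the step follows the methoxy group, the aromatic ring or the carbon link to that ring. A plain benzyl or phenyl group at this carbon would help separate these.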